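A few compounds are considered here, and "the series" means these few. Any claim that something is new, unique, unknown or untested is made for them only; others in the source may bear on it.

Working notes on the series. Compound 1 `COC(=O)c1ccc(NCc2cncn2Cc2ccccc2Cl)cc1-c1ccccc1` carries chloro, compound 2 `COC(=O)c1ccc(NCc2cncn2Cc2ccccc2N)cc1-c1ccccc1` amino in its place, and compound 3 `COC(=O)c1ccc(NCc2cncn2Cc2ccc(-c3ccccc3)cc2)cc1-c1ccccc1` 4-phenylphenyl in place of the 2-chlorophenyl. In a toxicity assay on NIH3T3 cells (Mus musculus) for cytotoxicity, read by resazurin assay (a higher number here means that more compound is needed for the effect, a lower number that less compound is needed), compound 1 gives 10000 nM and compound 2 gives 25000 nM, the difference being a 2.5-fold higher number from compound 1 to compound 2 (0.40 log units; beyond the scatter). For compound 3 the assay reports only a limit, > 1000 nM, which is not a number, so compound 3 stands at the limit of > 1000 nM in this assay, at which 1 of the 3 values shown sits. With that limit, a step that the limit leaves unreadable from compound 1 to compound 3 and a step that the limit leaves unreadable from compound 2 to compound 3 remain without a readable size.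

Compound 4 `CC(=O)c1ccc(NCc2cncn2Cc2ccc(-c3ccccc3)cc2)cc1-c1ccccc1` differs from compound 3 by methyl in place of methoxy on a carbonyl carbon. Among the compounds with values here, none of the measured steps touches the carbonyl carbon: the only sized step, a 2.5-fold higher number from compound 1 to compound 2 (0.40 log units; beyond the scatter), concerns the aromatic carbon bearing chloro or amino, and the two others are unreadable. No step beyond the scatter is expected, and the step from compound 3 to compound 4 is estimated as a step that the limit leaves unreadable from compound 3 to compound 4. Compound 4 is expected to give 10000 nM, within a range from 2000 nM to 50000 nM, with a fair chance that the assay again reports only a limit.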

Compound 4, half-maximal effective concentration: > 10000 nM
Compound 4 was reported as a limit; the forecaster's own chance of this, stated with the estimate: 40%; the middle value lies on the limit itself.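

Compound 3 and compound 4 are both reported only as limits in this assay, and no new step can be read between them. The compounds shown leave open what size, if any, the change from methoxycarbonyl to acetyl has in this assay.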